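Amino substitution on the pyridine of compound 2

The source may report more compounds than this note shows. Statements on the series, on what has been measured and on what is new or still open speak of the compounds shown alone.

Measured so far:
compound 1 `Nc1ccccc1NC(=O)c1ccc(Cn2cc(-c3ccc(NC(=O)NCc4cccnc4)cc3)nn2)cc1`, an assay on isolated protein for inhibition of Nicotinamide phosphoribosyltransferase (Homo sapiens), read by fluorescence, with stated times of 5 min and 15 min (a higher number here means a weaker inhibitor, a lower number a stronger inhibitor), 18 nM
compound 2 `Nc1ccccc1NC(=O)c1ccc(NC(=O)NCc2cccnc2)cc1`, this assay 550 nM

Compound 2 holds the highest number of the two measured. Among the compounds with values here, its only neighbour is compound 1, whose number lies far lower, beyond the usual scatter; no single-change step between measured compounds is available, so the two values are simply set side by side.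

Compound 3 `Nc1ccc(CNC(=O)Nc2ccc(C(=O)Nc3ccccc3N)cc2)cn1` is not yet measured in this assay. It differs from compound 2 in one place: amino in place of hydrogen on an aromatic carbon. The entering group carries one hydrogen-bond donor and one hydrogen-bond acceptor and sits on the six-membered aromatic ring with one nitrogen, next to the ring nitrogen and para to a large group.

With no measured step of this kind in the series, no direction can be read from the data. The change is small and the expected step of a 1.1-fold higher number from compound 2 to compound 3 (0.04 log units; within the scatter) is none beyond the scatter. Compound 3 is therefore estimated at 600 nM, with a range from 200 nM to 2000 nM.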

Compound 3, half-maximal inhibitory concentration: > 2000 nM
Compound 3 gave a limit, no number (the forecaster's own chance of this, stated with the estimate: 5%); middle value at least 3.3-fold (0.52 log units) away from the limit.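

In this assay compound 3 gives > 2000 nM, which is a limit of the assay and not a number. Within the data shown here, this is the first measured step at this place, and it gives the change a direction: amino in place of hydrogen on an aromatic carbon, next to the ring nitrogen and para to a large group, gives an at least 3.6-fold higher number from compound 2 to compound 3 (0.56 log units; beyond the scatter), so pyridin-3-yl to 6-aminopyridin-3-yl weakens inhibition rather than leaving it unchanged. The step fixes only a lower bound on the size of the change, and how much weaker compound 3 is than that bound remains unknown, with the reading resting on a single censored value: the limit of > 2000 nM in this assay, at which 1 of the 3 values shown sits.

The compounds shown do not tell whether this drop belongs to the amino group itself or to any substituent on this carbon, a question that a methyl, a hydroxyl or a fluorine at the same place would address. As far as these compounds go, it also remains open whether the 6-aminopyridin-3-yl group costs as much on the longer triazole-free or triazole-bearing frame of compound 1, whose core differs from that of compound 2.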